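The compounds below may be only part of what the source reports. "The series", "measured", "known", "first", "only" and "open" are said of these compounds alone.

Measured compounds, intrinsic activity in an assay on ileum (strain Hartley) with 5-hydroxytryptamine receptor 3A (Cavia porcellus) as the target; a lower number here means a smaller maximal response, a higher number a larger maximal response:

- compound 1 `CN1CCN(c2nc3cccc(Cl)c3o2)CC1`: 0.24
- compound 2 `COc1ccc2oc(N3CCN(C)CC3)nc2c1`: 0.78
- compound 3 `CN1CCN(c2nc3cc(F)ccc3o2)CC1`: 0.64

Compound 1 stands lowest of the three in this assay; its nearest neighbour is compound 3, which sits higher by a margin beyond the scatter, and compound 2 sits further above still. Among the compounds with values here, the one single-point step available is a number 0.14 lower from compound 2 to compound 3 (beyond the scatter), a change among substituents on the six-membered carbon ring of the shared core.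

Compound 4 `CN1CCN(c2nc3cc(Cl)cc(Cl)c3o2)CC1` differs from compound 1 by chloro in place of hydrogen on an aromatic carbon. Within the data shown here, no measured pair tests a chloro entering in place of hydrogen, nor a second halogen on a ring that already carries one; the step from compound 2 to compound 3 concerns a different exchange and only indicates that changes on this ring move the maximal response by a modest amount. With compound 1 already near the bottom of the range, the step from compound 1 to compound 4 in this assay is expected to be small, a number 0.060 higher from compound 1 to compound 4 (within the scatter), with the direction uncertain. Compound 4 is therefore estimated at 0.3 in this assay, within 0.12 to 0.55.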

Compound 4, intrinsic activity: the largest response reached, as a fraction of the reference agonist's: 0.14
Beside the measured number, compound 4's estimate is 0.16 above it; the range from low to high includes it.
By their numbers in this assay, from the lowest: compounds 4 and 1 (each within the scatter of the next); then compound 3; then compound 2.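

In this assay, chloro in place of hydrogen at the ring carbon meta to a chloro group and para to a fused ring gives a number 0.10 lower from compound 1 to compound 4 (within the scatter), so the response of this pair cannot be told apart. Within the data shown here, this is the first read on a second halogen entering a ring that already carries one, which the earlier fluoro-for-methoxy step could not address, and at this position the added chloro produces no shift beyond repeat variation. No measurement at hand accounts for this result.

As far as these compounds go, whether an amine or a carboxylic acid at this position would shift the maximal response remains open, as does the response with chloro here and no other chloro group on the ring. One pair also cannot show whether this step would hold with the substituents of compound 2 or compound 3.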